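The source may hold more compounds than are shown below. What is called first, only, known or untested is meant among the compounds shown, and "the series" means these compounds.

Working notes on the series. All three measured compounds share one core bearing a carboxymethyl group and were run in an in vitro assay on HEK385-7 cells for displacement of a labelled ligand from prostaglandin D2 receptor 2 (Homo sapiens); on this read-out higher numbers stand for weaker inhibition and lower numbers for stronger inhibition. Compound 1 `O=C(O)Cc1sc(CS(=O)(=O)c2ccc(Cl)cc2)nc1-c1ccc(Cl)cc1` gives 1500 nM in this assay. Compound 2 `O=C(O)Cc1sc(COc2ccc(Cl)cc2)nc1-c1ccc(Cl)cc1` gives 32 nM. Compound 3 `O=C(O)Cc1sc(C(c2ccc(F)cc2)c2ccc(F)cc2)nc1-c1cccc(F)c1` gives 1.4 nM, the lowest of the three numbers; the gap to compound 2, the nearest, and the wider gap to compound 1, the furthest, both lie beyond the scatter. Within the data shown here, no two measured compounds differ in a single place, so none of these gaps can be read as the effect of one change; compounds 1, 2 and 3 differ from one another at several positions at once.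

Compound 4 `O=C(O)Cc1sc(C(c2ccc(F)cc2)c2ccc(F)cc2)nc1-c1ccco1` differs from compound 3 in one place only: furan-2-yl in place of 3-fluorophenyl on an aromatic carbon. Among the measured compounds shown here, no measured pair carries this change, and the three measured compounds give no direct guide to its size or direction. The step of a 2.9-fold higher number from compound 3 to compound 4 (0.46 log units; beyond the scatter) is therefore expected to be small, toward a higher number, and close to the edge of the scatter rather than clearly beyond it. On that basis compound 4 is estimated at 4 nM in this assay, with a range from 1.2 nM to 14 nM.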

Compound 4, half-maximal inhibitory concentration: 18 nM
Beside the measured number, compound 4's estimate is 4.5-fold (0.65 log units) below it; measured number above the stated range.
By their numbers in this assay, from the lowest: compound 3; then compounds 4 and 2 (each within the scatter of the next); then compound 1.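

In this assay the position next to the ring nitrogen and next to the ring atom that bears a carboxymethyl group proves sensitive to the group it carries: furan-2-yl in place of 3-fluorophenyl gives a 13-fold higher number from compound 3 to compound 4 (1.11 log units; beyond the scatter), a large step and the first in the series that can be read as a single change. Among these compounds, the earlier compounds differed at several positions at once, so only this pair shows that this position alone can move the number by more than the scatter while the rest of compound 3 stays fixed. The change replaces a six-membered aromatic ring of carbon only with a five-membered aromatic ring with 1 hetero atom and also removes the fluorine, and no measurement shown here accounts for the step.

Which of these differences carries the step remains open, and phenyl or thiophen-2-yl at this position would help to separate ring size, the ring oxygen and the fluorine. From the compounds shown here alone, it is also open whether a step of this size would recur with a different large group on the shared core, such as a 4-chlorophenoxymethyl group.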